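The source may report more compounds than this note shows. Statements on the series, on what has been measured and on what is new or still open speak of the compounds shown alone.

In a functional assay on K562 cells (Homo sapiens) for antiproliferative activity, with a stated time of 72 h; a lower number here means a stronger inhibitor, a higher number a weaker inhibitor:
- compound 1 `CCCC#Cc1cc([C@@H]2O[C@H](CO)[C@@H](O)[C@H]2O)n2ncnc(N)c12`: 1100 nM
- compound 2 `CCCCC#Cc1cc([C@@H]2O[C@H](CO)[C@@H](O)[C@H]2O)n2ncnc(N)c12`: 2400 nM
- compound 3 `Nc1ncnn2c([C@@H]3O[C@H](CO)[C@@H](O)[C@H]3O)cc(C#Cc3ccc(F)cc3)c12`: > 100000 nM (a limit of the assay, not a number)

Compound 3 thus has no measured number, only a limit, as the limit of > 100000 nM in this assay, at which 1 of the 3 values shown sits, records. Compound 4 `Nc1ncnn2c([C@@H]3O[C@H](CO)[C@@H](O)[C@H]3O)cc(C#Cc3cccs3)c12` carries thiophen-2-yl in place of 4-fluorophenyl on a triple-bonded carbon. The relevant steps are the large losses on replacing an alkyl chain with 4-fluorophenyl, an at least 90-fold higher number from compound 1 to compound 3 (1.95 log units; beyond the scatter) and an at least 41-fold higher number from compound 2 to compound 3 (1.61 log units; beyond the scatter). Chain extension gave only a modest change, a 2.2-fold higher number from compound 1 to compound 2 (0.34 log units; beyond the scatter). Among the compounds with values here, no measured step exchanges one aromatic ring for another, so compound 4 is expected to stay weak, with at most a small shift towards lower numbers in this assay. The expected change is an at least 1.6-fold lower number from compound 3 to compound 4 (0.22 log units; that floor lies within the scatter). For compound 4 the estimate is 60000 nM, with an expected range of 10000 nM to 100000 nM.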

Compound 4, half-maximal inhibitory concentration: > 100000 nM
Compound 4: a limit, no number; the forecaster's own chance of this, stated with the estimate: 55%; middle value at least 1.6-fold (0.22 log units) away from the limit.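

In this assay compound 4 gives > 100000 nM as a limit of the assay, not a number. The loss on leaving the alkyl chains is not confined to 4-fluorophenyl, since thiophen-2-yl on the triple-bonded carbon also gives a large step in each comparison (an at least 90-fold higher number from compound 1 to compound 4 (1.95 log units; beyond the scatter); an at least 41-fold higher number from compound 2 to compound 4 (1.61 log units; beyond the scatter)). The step from 4-fluorophenyl to thiophen-2-yl cannot be read, with both compounds at the same limit: the limit of > 100000 nM in this assay, at which 2 of the 4 values shown sit.

Going by these compounds, how compound 3 and compound 4 rank remains open. Also open, on these data alone, is whether a cyclopropyl or a hydroxymethyl group on the triple-bonded carbon would keep the activity of the alkyl chains.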